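The compounds below may be only part of what the source reports. "The series", "measured", "known", "first", "only" and "open" are said of these compounds alone.

In a functional assay on HCT-116 cells (Homo sapiens) for inhibition, read by MTT assay, with a stated time of 72 h (a higher number here means a weaker inhibitor, a lower number a stronger inhibitor), three compounds have been measured:

- compound 1 `O=C1/C(=C\c2ccccc2)c2c(ncn2COCc2ccccc2)CCN1Cc1ccccc1`: 20000 nM
- compound 2 `Cc1cc(C)cc(CN2CCc3ncn(COCc4ccccc4)c3/C(=C/c3ccccc3)C2=O)c1`: 6230 nM
- compound 3 `Cc1cccc(CN2CCc3ncn(COCc4ccccc4)c3/C(=C/c3ccccc3)C2=O)c1`: 3800 nM

Compound 3 stands at the low end of this short series, although it cannot be separated from compound 2. Against compound 1, the difference lies beyond the scatter. The unmeasured compound 4 `COc1ccc(CN2CCc3ncn(COCc4ccccc4)c3/C(=C/c3ccccc3)C2=O)cc1` carries 4-methoxyphenyl in place of 3-methylphenyl on a saturated chain carbon bound to an amide-type nitrogen in a ring.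

For the measured compounds named here, no measured step makes this exact exchange. The nearest evidence is that replacing the unsubstituted phenyl gave two modest steps, a 3.2-fold lower number from compound 1 to compound 2 (0.51 log units; beyond the scatter) and a 5.3-fold lower number from compound 1 to compound 3 (0.72 log units; beyond the scatter). The exchange of one substituted ring for another was smaller, a 1.6-fold lower number from compound 2 to compound 3 (0.21 log units; within the scatter). On the strength of that last step, no change beyond the scatter is expected in this assay. The estimated step is a 1.3-fold higher number from compound 3 to compound 4 (0.12 log units; within the scatter). Compound 4 is expected at about 5000 nM, with an estimated range of 1800 nM to 14000 nM.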

Compound 4, half-maximal inhibitory concentration: 31100 nM
Beside the measured number, compound 4's estimate is 6.2-fold (0.79 log units) below it; the whole stated range lies below it.
By their numbers in this assay, from the lowest: compounds 3 and 2 (each within the scatter of the next); then compounds 1 and 4 (each within the scatter of the next).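

In this assay, the earlier exchange of one substituted ring for another had stayed within the scatter, but this position now proves sensitive to which substituted ring it carries: 4-methoxyphenyl gives an 8.2-fold higher number from compound 3 to compound 4 (0.91 log units; beyond the scatter) in place of 3-methylphenyl and a 5.0-fold higher number from compound 2 to compound 4 (0.70 log units; beyond the scatter) in place of 3,5-dimethylphenyl. Methoxy in place of hydrogen gives a 1.6-fold higher number from compound 1 to compound 4 (0.19 log units; within the scatter), which is within the scatter, so compound 4 cannot be separated from the unsubstituted phenyl of compound 1. The lower numbers at this position therefore do not extend to every substituted ring: among these four compounds, they belong only to the two methyl-bearing rings.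

Because 3-methylphenyl and 4-methoxyphenyl differ in both the group and its place on the ring, the compounds shown cannot separate those two changes, and they leave open how an amine or a carboxylic acid on this ring would read. Nothing available explains this result.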